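The compounds below may be only part of what the source reports. "The series", "measured", "known", "first", "only" and "open" are said of these compounds alone.

Measured compounds:
- compound 1 `COc1ccccc1Oc1cncc(C2=CC3CNCC(C2)C3)c1`: 1 nM
- compound 2 `CN1C[C@H]2C=C(c3cccnc3)C[C@H](C2)C1`: 2.1 nM
- compound 3 `COc1cc(C2=CC3CNCC(C2)C3)cnc1Cl`: 0.4 nM

The three compounds were characterised in an in vitro assay on SH-EP1 cells for displacement of a labelled ligand from Neuronal acetylcholine receptor; alpha4/beta2 (Homo sapiens); on this read-out higher numbers stand for weaker inhibition and lower numbers for stronger inhibition. Compound 1 gives 1 nM, which places it second highest among the three numbers. Compound 2 gives 2.1 nM, a higher number than compound 1 by a margin beyond the usual scatter. Compound 3 gives 0.4 nM, a lower number than compound 1, again beyond the scatter. Among the compounds with values here, no pair among the three differs in only one place, so no single step can be read from them.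

The piece now turns to compound 4 `COc1ccc(Oc2cncc(C3=CC4CNCC(C3)C4)c2)cc1`, which has not yet been measured in this assay. It is built from the same atoms as compound 1, joined differently: 4-methoxyphenyl in place of 2-methoxyphenyl on an oxygen on an aromatic ring. Within the data shown here, nothing among the measured compounds separates the two methoxyphenyl arrangements, so the direction of the change has to be guessed. The account expects a step from compound 1 to compound 4 of a 2.0-fold higher number from compound 1 to compound 4 (0.30 log units; within the scatter), a modest move toward a higher number that may well sit within the scatter. On that basis compound 4 is estimated at 2 nM in this assay, with a plausible range from 0.5 nM to 8 nM.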

Compound 4, inhibition constant: 1.4 nM
For compound 4 the middle estimate is 1.4-fold (0.15 log units) above the measured one; the range from low to high includes it.
By their numbers in this assay, from the lowest: compound 3; then compounds 1, 4 and 2 (each within the scatter of the next, the first and the last beyond it).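

This is the first pair among the compounds shown that differs in only one place, so it gives the first step that can be read at all. In this assay, 4-methoxyphenyl in place of 2-methoxyphenyl on an oxygen on an aromatic ring gives a 1.4-fold higher number from compound 1 to compound 4 (0.15 log units; within the scatter), which means that this read-out does not separate the two methoxyphenyl arrangements at this position, and neither can be ranked above the other. Nothing available here offers an explanation for the two compounds reading alike.

The compounds shown leave open whether 3-methoxyphenyl on the same oxygen would also read like compound 1 and compound 4, and whether the methoxy group matters at all, as neither a plain phenyl nor a phenyl carrying a carboxylic acid or an amine stands among them. Within the data shown here, they also leave open what the whole group on that oxygen contributes, as compound 2 and compound 3 each differ from compound 1 in more than one place and give no step that can be read against it.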